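A few compounds are considered here, and "the series" means these few. Any claim that something is new, unique, unknown or untested is made for them only; others in the source may bear on it.

Measured so far:
Compound 1 `Fc1ccc(C(SCCNC2CCN(Cc3ccc(C(F)(F)F)cc3)CC2)c2ccc(F)cc2)cc1`: in an assay on membranes from striatum (strain Sprague-Dawley) for displacement of a labelled ligand from sodium-dependent dopamine transporter (Rattus norvegicus), read by scintillation counting, with a stated time of 120 min (on this read-out lower numbers stand for stronger inhibition and higher numbers for weaker inhibition), compound 1 gives 190 nM.
Compound 2 `O=C(C1CC1)N1CCC(NCCSC(c2ccc(F)cc2)c2ccc(F)cc2)CC1`: in this assay compound 2 gives 178 nM.

On the two numbers shown, compound 2 stands side by side with compound 1: the only measured step, a 1.1-fold lower number from compound 1 to compound 2 (0.03 log units; within the scatter), lies within the scatter, so the two compounds cannot be separated on this read-out. Compound 3 `CC(C)(C)CN1CCC(NCCSC(c2ccc(F)cc2)c2ccc(F)cc2)CC1` is not yet measured. It differs from compound 2 in one place: neopentyl in place of cyclopropylcarbonyl on an amine nitrogen in a ring. For the measured compounds named here, the single measured step bears on this only loosely: a 1.1-fold lower number from compound 1 to compound 2 (0.03 log units; within the scatter) shows that exchanging one group for another on that same ring nitrogen kept the number within the scatter, and no measured pair shows what a neopentyl group does there. Nothing in the data points to a shift in either direction, so the expected step in this assay is a 1.0-fold higher number from compound 2 to compound 3 (0.00 log units; within the scatter), none beyond the scatter. Compound 3 is therefore estimated at 180 nM, with a range from 60 nM to 550 nM.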

Compound 3, inhibition constant: 279 nM
Compound 3: the middle estimate sits 1.6-fold (0.19 log units) below what was measured; the measured number falls inside the stated range.
By their numbers in this assay, from the lowest: compounds 2, 1 and 3 (each within the scatter of the next).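

In this assay the ring nitrogen now carries a third kind of group, and the numbers still cannot be told apart: a 1.6-fold higher number from compound 2 to compound 3 (0.20 log units; within the scatter) lies within the scatter, and so does a 1.5-fold higher number from compound 1 to compound 3 (0.17 log units; within the scatter). The earlier pair did not show that this position could go without a carbonyl, but neopentyl, with no ring and no hydrogen-bond acceptor, leaves the number within the scatter of both cyclopropylcarbonyl and 4-(trifluoromethyl)benzyl. No measurement here accounts for this result.

The compounds shown leave open whether any group on this nitrogen moves the number beyond the scatter. A carboxylic acid on a short chain, or a plain hydrogen in place of the whole group, would test this in a way that these three neutral groups cannot.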